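This account rests on a few compounds, and the source may have more. Where it says the series, first, only, none or still open, it means among the compounds named here.

Compound 1 (`O=C1CCCC/C1=C\c1ccc(OC(=O)c2ccccc2)cc1`) reaches only a limit in a functional assay on P388 cells (Mus musculus) (on this read-out lower numbers stand for stronger inhibition and higher numbers for weaker inhibition), > 50000 nM. Going by the values given here, compound 2 (`O=C1CCCC/C1=C\c1ccc(OC(=O)c2ccc(Cl)cc2)cc1`) gives 25500 nM, the only actual number so far. Compound 3 (`Cc1ccc(C(=O)Oc2ccc(/C=C3\CCCCC3=O)cc2)cc1`) keeps the shared core and changes one group: methyl in place of chloro on an aromatic carbon. Among the compounds with values here, one measured step bears on this, an at least 1.9-fold lower number from compound 1 to compound 2 (0.29 log units; that floor lies within the scatter), with chloro in place of hydrogen. Its size is only a floor because of the limit of > 50000 nM in this assay, at which 1 of the 2 values shown sits. No shift beyond the scatter is therefore expected in this assay, in either direction. The expected change is a 1.2-fold higher number from compound 2 to compound 3 (0.07 log units; within the scatter). For compound 3, the estimated value is 30000 nM, with an expected range of 13000 nM to 60000 nM.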

Compound 3, half-maximal inhibitory concentration: > 50000 nM
Compound 3 ended at the assay's limit (the forecaster's own chance of this, stated with the estimate: 35%); at least 1.6-fold (0.22 log units) between middle value and limit.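

In this assay, methyl in place of chloro on this aromatic carbon gives an at least 1.9-fold higher number from compound 2 to compound 3 (0.29 log units; that floor lies within the scatter). Compound 2 therefore remains the only one of the three with an actual number, yet this change shows no shift beyond the scatter, and its size is only a floor: the limit of > 50000 nM in this assay, at which 2 of the 3 values shown sit. The step between compound 1 and compound 3 cannot be read, as both values are limits.

On these data alone, whether any group here moves the number beyond the scatter stays open. An amine or a carboxylic acid at this place could answer that.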